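From allyl to 4-fluorophenyl on the thiocarbonyl nitrogen

The source may report more compounds than this note shows. Statements on the series, on what has been measured and on what is new or still open speak of the compounds shown alone.

In a functional assay on KB-V1 cells (Homo sapiens) for cytotoxicity, read by MTT assay, with a stated time of 72 h (on this read-out lower numbers stand for stronger inhibition and higher numbers for weaker inhibition), compound 1 (`O=C1Nc2ccccc2/C1=N/NC(=S)Nc1ccc2c(c1)CCC2`) gives 2850 nM while compound 2 (`C=CCNC(=S)N/N=C1\C(=O)Nc2ccccc21`) stands higher, the weaker of the two, at 20700 nM with a gap beyond the scatter. Compound 3 (`O=C1Nc2ccccc2/C1=N/NC(=S)Nc1ccc(F)cc1`) has 4-fluorophenyl in place of allyl on an amide-type nitrogen. Among the compounds with values here, no measured pair isolates a change like this one. Where compound 2 has allyl, compound 1 carries an aromatic ring and gives 2850 nM as the only guide. The expected change is a 4.1-fold lower number from compound 2 to compound 3 (0.62 log units; beyond the scatter) toward a lower number, beyond the scatter. Compound 3 is estimated at 5000 nM with 1700 nM to 14000 nM as its expected range.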

Compound 3, half-maximal inhibitory concentration: 1920 nM
Compound 3: the middle estimate sits 2.6-fold (0.42 log units) above what was measured, within the range that was stated.
By their numbers in this assay, from the lowest: compounds 3 and 1 (each within the scatter of the next); then compound 2.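

In this assay the position now has a direct reading: 4-fluorophenyl in place of allyl on the amide-type nitrogen brings an 11-fold lower number from compound 2 to compound 3 (1.03 log units; beyond the scatter) and so turns the indirect hint from compound 1 into a measured step. Compound 3 and compound 1 lie within the scatter of each other, so these two aromatic groups read alike here. No measurement at hand explains the step. The compounds shown leave open whether an unsubstituted phenyl, a benzyl or a cyclohexyl on this nitrogen would read the same.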